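Acetyl in place of methylsulfanyl: the expected step

This account rests on a few compounds, and the source may have more. Where it says the series, first, only, none or still open, it means among the compounds named here.

In a functional assay on MDA-MB-231 cells (Homo sapiens) for antiproliferative activity, read by MTT assay, with a stated time of 72 h (a lower number here means a stronger inhibitor, a higher number a weaker inhibitor), compound 1 `O=C(CCc1cccc2c1B(O)OC2)Nc1cccc(Br)c1` gives 720 nM, compound 2 `C#Cc1cccc(NC(=O)CCc2cccc3c2B(O)OC3)c1` gives 1600 nM, and compound 3 `CSc1cccc(-c2cccc(NC(=O)CCc3cccc4c3B(O)OC4)c2)c1` gives 150 nM. Compound 3 has the lowest of the three numbers, and its steps to both others lie beyond the scatter.

Compound 4 `CC(=O)c1cccc(-c2cccc(NC(=O)CCc3cccc4c3B(O)OC4)c2)c1` carries acetyl in place of methylsulfanyl on an aromatic carbon, (acetyl in place of methylsulfanyl on an aromatic carbon). The change sits on a six-membered aromatic ring of carbon only, meta to a large group, and can also be read as 3-(methylsulfanyl)phenyl to 3-acetylphenyl.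

Within the data shown here, no measured step exchanges these two groups. The closest evidence is the pair of steps that introduce 3-(methylsulfanyl)phenyl: modest in a 4.8-fold lower number from compound 1 to compound 3 (0.68 log units; beyond the scatter) and large in an 11-fold lower number from compound 2 to compound 3 (1.03 log units; beyond the scatter). The step of a 2.2-fold higher number from compound 1 to compound 2 (0.35 log units; beyond the scatter) is modest and involves neither group. Compound 4 retains the phenyl ring and differs only in the group on it, so a number near that of compound 3 is expected, with a slight rise the more likely direction. In this assay the expected step is a 1.5-fold higher number from compound 3 to compound 4 (0.17 log units; within the scatter), small and probably within the scatter. For compound 4 the estimated value is 220 nM, with an expected range of 90 nM to 550 nM.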

Compound 4, half-maximal inhibitory concentration: 52 nM
Beside the measured number, compound 4's estimate is 4.2-fold (0.63 log units) above it; the measured number lies below the stated range.
By their numbers in this assay, from the lowest: compound 4; then compound 3; then compound 1; then compound 2.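

In this assay, the group carried on the added phenyl ring matters as well as the ring itself: a 2.9-fold lower number from compound 3 to compound 4 (0.46 log units; beyond the scatter), so this place on the ring still responds to a one-group exchange. The 3-acetylphenyl group also gives larger steps than 3-(methylsulfanyl)phenyl did from the smaller starting groups, with a 14-fold lower number from compound 1 to compound 4 (1.14 log units; beyond the scatter) against a 4.8-fold lower number from compound 1 to compound 3 (0.68 log units; beyond the scatter) on replacing bromo, and a 31-fold lower number from compound 2 to compound 4 (1.49 log units; beyond the scatter) against an 11-fold lower number from compound 2 to compound 3 (1.03 log units; beyond the scatter) on replacing ethynyl. Nothing available accounts for the lower number with acetyl than with methylsulfanyl.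

The compounds shown leave open whether the carbonyl of acetyl is the feature that matters at this place, a question that a carboxylic acid, a primary amide or a longer ketone such as propanoyl on the same aromatic carbon would help to settle. They also leave open whether acetyl keeps its lead over methylsulfanyl on another carbon of the same ring.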